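The source may report more compounds than this note shows. Statements on the series, on what has been measured and on what is new or still open speak of the compounds shown alone.

Measured compounds in an ADME assay on HepG2 cells (Homo sapiens) for cytotoxicity, read by MTT assay, with a stated time of 24 h; on this read-out lower numbers stand for higher toxicity in this test and higher numbers for lower toxicity in this test:

Compound 1, `COc1cccc(CC/C=C(\C)CCC=C(C)C)c1`, gives > 100000 nM, a limit of the assay and not a number.
Compound 2, `CC1=C(C(O)Cc2ccc(C(C)(C)C)cc2)C(C)(C)CCC1`, gives > 100000 nM, likewise a limit.
Compound 3, `COc1cc(CC(O)C2=C(C)CCCC2(C)C)cc(OC)c1OC`, gives > 100000 nM, again only a limit.

Compound 2 therefore has no numerical position in this assay; its value sits at the limit of > 100000 nM in this assay, at which 3 of the 3 values shown sit, together with the other two shown. For the measured compounds named here, no step between measured compounds is available, so no measured direction can be read from this set.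

Compound 4, `COc1ccc(CC(O)C2=C(C)CCCC2(C)C)cc1`, is the next one to be run in this assay. It differs from compound 2 by methoxy in place of tert-butyl on an aromatic carbon. Given that every value shown is a limit, compound 4 is expected to return a limit as well, with a number no higher from compound 2 to compound 4 (the limit leaves the size open) giving no step beyond the scatter. The estimate for compound 4 in this assay is 100000 nM, within 40000 nM to 300000 nM.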

Compound 4, half-maximal cytotoxic concentration: > 100000 nM
Compound 4 ended at the assay's limit; the forecaster's own chance of this, stated with the estimate: 85%; the middle value lies on the limit itself.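

In this assay, compound 2 and compound 4 both stand at a limit of the assay, so no step can be read for methoxy in place of tert-butyl. The compounds shown leave open whether any structural change gives a numerical value.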